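Removing a methoxy from compound 1

The compounds below may be only part of what the source reports. "The series", "measured", "known", "first", "only" and "open" are said of these compounds alone.

Compound 1 `COc1ccc(/C=C/C2(C)C=CC(=O)O2)cc1OC`: 111000 nM
Compound 2 `COc1ccc(/C=C/C2(C)C=CC(=O)O2)c(OC)c1OC`: 349000 nM
Compound 3 `COc1cc(OC)c(OC)cc1/C=C/C1(C)C=CC(=O)O1`: 158000 nM

In a functional assay on NCI/ADR-RES cells (Homo sapiens) for inhibition, read by sulforhodamine B assay, with a stated time of 48 h (a lower number here means a stronger inhibitor of growth, a higher number a weaker inhibitor of growth), compound 1 gives 111000 nM, which places it at the low end of the set. Compound 4 `COc1cccc(/C=C/C2(C)C=CC(=O)O2)c1` differs from it by hydrogen in place of methoxy on an aromatic carbon. Among the compounds with values here, no measured step removes a methoxy. The nearest evidence is two methoxy additions at other carbons, a 1.4-fold higher number from compound 1 to compound 3 (0.15 log units; within the scatter) and a 3.1-fold higher number from compound 1 to compound 2 (0.50 log units; beyond the scatter). They bear on this change only loosely, and their sizes differ, so no clear direction is expected. The expected step is a 1.1-fold higher number from compound 1 to compound 4 (0.05 log units; within the scatter), which would not go beyond the scatter. Compound 4 is estimated at 125000 nM, with an expected range of 60000 nM to 260000 nM.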

Compound 4, concentration for total growth inhibition: 48600 nM
Beside the measured number, compound 4's estimate is 2.6-fold (0.41 log units) above it, and the stated range ends above it.
By their numbers in this assay, from the lowest: compound 4; then compounds 1 and 3 (each within the scatter of the next); then compound 2.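

In this assay, within the data shown here, the methoxy at this position proves not to be neutral: replacing it with hydrogen gives a 2.3-fold lower number from compound 1 to compound 4 (0.36 log units; beyond the scatter), the first step in the set towards a lower number. The earlier steps shown here only added methoxy groups at other carbons, and these gave a 3.1-fold higher number from compound 1 to compound 2 (0.50 log units; beyond the scatter) and a 1.4-fold higher number from compound 1 to compound 3 (0.15 log units; within the scatter), so fewer methoxy groups do not always change the number, as compound 3 shows. Nothing measured here explains the shift.

The compounds shown leave open whether a hydroxyl, a fluorine or an amine at this carbon would read like the hydrogen or like the methoxy. They also leave open what the remaining methoxy contributes.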